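Amino in place of methyl: compound 3 to compound 4

A few compounds are considered here, and "the series" means these few. Any claim that something is new, unique, unknown or untested is made for them only; others in the source may bear on it.

Values in a functional assay on KYSE-450 cells (Homo sapiens) for inhibition, read by CCK-8 assay, with a stated time of 48 h; a lower number here means a stronger inhibitor, a higher number a weaker inhibitor:
- Compound 1 `COc1cc(N(Cc2ccc(C)cc2)C(=O)CSC(=S)N2CCN(C(=O)OC(C)(C)C)CC2)cc(OC)c1OC`: > 20000 nM (a limit)
- Compound 2 `COc1ccc(CN(C(=O)CSC(=S)N2CCN(C(=O)OC(C)(C)C)CC2)c2cc(OC)c(OC)c(OC)c2)cc1F`: 2410 nM
- Compound 3 `COc1ccc(CN(C(=O)CSC(=S)N2CCN(C(=O)OC(C)(C)C)CC2)c2cc(OC)c(OC)c(OC)c2)cc1C`: > 20000 nM (a limit)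

Compound 3 gives > 20000 nM, which is a limit and not a number. It shares this position with compound 1, as the limit of > 20000 nM in this assay, at which 2 of the 3 values shown sit, records. Compound 4 `COc1ccc(CN(C(=O)CSC(=S)N2CCN(C(=O)OC(C)(C)C)CC2)c2cc(OC)c(OC)c(OC)c2)cc1N` carries amino in place of methyl on an aromatic carbon, ortho to a methoxy group: amino in place of methyl on an aromatic carbon.

The nearest measured step is methyl in place of fluoro on an aromatic carbon, with an at least 8.2-fold higher number from compound 2 to compound 3 (0.91 log units; beyond the scatter). The change of benzyl substituents gives an at least 8.2-fold lower number from compound 1 to compound 2 (0.91 log units; beyond the scatter), while a step that the two limits leave unreadable from compound 1 to compound 3 gives no usable size. Only compound 2 has a measured number in this assay, at 2410 nM, so it is the expected reference point once the methyl of compound 3 is gone. A return to the limit remains possible.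

The expected change is an at least 8.0-fold lower number from compound 3 to compound 4 (0.90 log units; beyond the scatter), a drop of at least modest size. For compound 4 the estimated value is 2500 nM. The expected range for compound 4 runs from 400 nM to 16000 nM.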

Compound 4, half-maximal inhibitory concentration: 208 nM
Beside the measured number, compound 4's estimate is 12-fold (1.08 log units) above it, and the stated range ends above it.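

In this assay, the aromatic carbon ortho to a methoxy group proves far more sensitive than the fluoro and methyl pair alone could show: amino in place of methyl gives an at least 96-fold lower number from compound 3 to compound 4 (1.98 log units; beyond the scatter). Amino also goes beyond fluoro, the only earlier group here with a measured number, giving a 12-fold lower number from compound 2 to compound 4 (1.06 log units; beyond the scatter), and the full change of benzyl substituent gives an at least 96-fold lower number from compound 1 to compound 4 (1.98 log units; beyond the scatter). The steps from compound 1 and compound 3 therefore give minimum sizes only, starting from a limit and not a number: the limit of > 20000 nM in this assay, at which 2 of the 4 values shown sit.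

As far as these compounds go, whether the amino hydrogens matter stays open; a dimethylamino or an acetamido group on this carbon would separate them from the nitrogen itself. The compounds shown also leave open whether the amino group keeps its effect without the neighbouring methoxy group, as in 3-aminobenzyl.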